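The compounds below may be only part of what the source reports. "The series", "measured", "known", "first", "only" and "open" are said of these compounds alone.

Of the compounds shown here, two share one core and have been measured in a functional assay on HT-29 cells (Homo sapiens) for cytotoxicity, read by sulforhodamine B assay, with a stated time of 2 days, tested at 100 uM; a higher number here means more inhibition at the concentration tested (going by the name of the read-out), a lower number less inhibition. Compound 1 `CCCCCc1nc2c(-c3ccc(Cl)cc3)n[nH]c2c(=O)n1NC(=O)c1cccc(C)c1` gives 90.5%, and compound 2 `Cc1cccc(C(=O)Nn2c(CC3CCCCC3)nc3c(-c4ccc(Cl)cc4)n[nH]c3c2=O)c1` gives 88.7%. Among the measured compounds shown here, the one change between them, cyclohexyl in place of butyl on a saturated chain carbon bound to an aromatic carbon, goes with a step of a number 1.8 percentage points lower from compound 1 to compound 2 (within the scatter), so the two numbers cannot be told apart. Compound 2 therefore stands beside compound 1 at a level that is, in this assay, level with it, with no gap between them beyond the scatter.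

Compound 3 `CC(C)(C)c1ccc(C(=O)Nn2c(CC3CCCCC3)nc3c(-c4ccc(Cl)cc4)n[nH]c3c2=O)cc1` has not yet been measured. It differs from compound 2 only on a carbonyl carbon whose other neighbour is an amide-type nitrogen: 4-(tert-butyl)phenyl in place of 3-methylphenyl on a carbonyl carbon. For the measured compounds named here, no measured step touches that part of the molecule; the single step seen so far changes a different group. There is thus nothing in the data that points to a large move in either direction, and the expectation is a step of a number 1.7 percentage points lower from compound 2 to compound 3 (within the scatter), not beyond the scatter. Compound 3 is accordingly expected to give about 87%, within a range from 68% to 97%.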

Compound 3, a percentage reported as inhibition, at one concentration (the size of the read-out at that concentration, not a potency): 72.4%
Compound 3: middle estimate off by 14.6 percentage points, on the high side; low and high end bracket the measured number.
By their numbers in this assay, from the lowest: compound 3; then compounds 2 and 1 (each within the scatter of the next).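

Among the compounds shown here, until now, the only step seen was the change on the chain carbon, which stayed within the scatter. In this assay, for the compounds shown here, the group on the carbonyl carbon whose other neighbour is the amide-type nitrogen proves to matter more: 4-(tert-butyl)phenyl in place of 3-methylphenyl goes with a number 16.3 percentage points lower from compound 2 to compound 3 (beyond the scatter) and is the first single change here to clear the scatter. The data offer no measurement that would account for this step.

The two groups differ both in what the ring carries and in where it carries it, and the compounds shown cannot separate those two changes, which 4-methylphenyl or 3-(tert-butyl)phenyl in the same place could begin to do. Also open, from the compounds shown here alone, are how a phenyl ring bearing an amine or a carboxylic acid would read at this position, and whether the same swap gives a similar step with butyl instead of cyclohexyl on the chain carbon.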